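Swapping the Benzylic Ring on Compound 2

This account rests on a few compounds, and the source may have more. Where it says the series, first, only, none or still open, it means among the compounds named here.

compound 1 `CC(C)(C)OC(=O)N(Cc1ccco1)C(=O)c1ccc(CN2Cc3ccccc3S2(=O)=O)cc1`: 10600 nM
compound 2 `CC(C)(C)OC(=O)N(Cc1ccco1)C(=O)c1ccc(CN2C(=O)c3ccccc3C2=O)cc1`: 3450 nM
compound 3 `O=C(NCc1ccco1)c1ccc(CN2C(=O)c3ccccc3C2=O)cc1`: 56000 nM

In a functional assay on RAW264.7 cells (Mus musculus) for inhibition (a higher number here means a weaker inhibitor, a lower number a stronger inhibitor), compound 2 holds the lowest of the three numbers; its two neighbours are reached by a 3.1-fold lower number from compound 1 to compound 2 (0.49 log units; beyond the scatter) and by a 16-fold higher number from compound 2 to compound 3 (1.21 log units; beyond the scatter). Compound 4 `CC(C)(C)OC(=O)N(Cc1ccco1)C(=O)c1ccc(Cn2oc3ccccc3c2=O)cc1` differs from compound 2 by a group of 10 heavy atoms (7 carbon, 1 nitrogen, 2 oxygen; one five-membered aromatic ring with 2 hetero atoms, one six-membered aromatic ring of carbon only) in place of a group of 11 heavy atoms (8 carbon, 1 nitrogen, 2 oxygen; one five-membered non-aromatic ring with 1 hetero atom, one six-membered aromatic ring of carbon only), on a saturated chain carbon bound to an aromatic carbon. Going by the values given here, only one measured step bears on this: the ring swap at the same place, a 3.1-fold lower number from compound 1 to compound 2 (0.49 log units; beyond the scatter), which was modest. The removal of the tert-butoxycarbonyl, a 16-fold higher number from compound 2 to compound 3 (1.21 log units; beyond the scatter), tells nothing about the benzylic ring. A step of modest size is therefore expected, with its direction uncertain. The estimated value for compound 4 is 5000 nM, with a range from 1500 nM to 17000 nM. This corresponds to an expected step of a 1.4-fold higher number from compound 2 to compound 4 (0.16 log units; within the scatter).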

Compound 4, half-maximal inhibitory concentration: 6690 nM
For compound 4 the middle estimate is 1.3-fold (0.13 log units) below the measured one; the range from low to high includes it.
By their numbers in this assay, from the lowest: compounds 2, 4 and 1 (each within the scatter of the next, the first and the last beyond it); then compound 3.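

At the saturated chain carbon bound to an aromatic carbon, the group with the five-membered aromatic ring with 2 hetero atoms gives a 1.9-fold higher number from compound 2 to compound 4 (0.29 log units; within the scatter) and a 1.6-fold lower number from compound 1 to compound 4 (0.20 log units; within the scatter) and so cannot be told apart from either, although compound 1 and compound 2 differ beyond the scatter. This place therefore tolerates a five-membered aromatic ring in this group without a readable change. Nothing measured here explains this result. Still open, as far as these compounds go, is whether an amine or a carboxylic acid at this place would give a step beyond the scatter. Also open, from the compounds shown here alone, is whether these ring groups would compare in the same way with hydrogen in place of tert-butoxycarbonyl, as in compound 3.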